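A second fluoro on the shared core

A few compounds are considered here, and "the series" means these few. Any claim that something is new, unique, unknown or untested is made for them only; others in the source may bear on it.

In a functional assay on the whole organism with Mus musculus as the target (on this read-out higher numbers stand for an effect only at larger amounts of compound and lower numbers for an effect already at smaller amounts), compound 1 `Cc1cccc2c1CC/C2=C\C(=O)NC1CC1` gives 40 mg/kg, and compound 2 `O=C(/C=C1\CCc2c(F)cccc21)NC1CC1` gives 126 mg/kg, the higher of the two numbers. Compound 3 `O=C(/C=C1\CCc2c1ccc(F)c2F)NC1CC1` comes from compound 2 through one change: fluoro in place of hydrogen on an aromatic carbon, ortho to a fluoro group. For the measured compounds named here, the only measured step, a 3.2-fold higher number from compound 1 to compound 2 (0.50 log units; beyond the scatter), was modest and replaced methyl rather than hydrogen, so it offers only a loose guide. A shift beyond the scatter in this assay is therefore not expected. The expected step is a 1.3-fold lower number from compound 2 to compound 3 (0.10 log units; within the scatter). Compound 3 is estimated at 100 mg/kg, with a range of 40 mg/kg to 250 mg/kg.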

Compound 3, dose for half-maximal effect: 62 mg/kg
Beside the measured number, compound 3's estimate is 1.6-fold (0.21 log units) above it; low and high end bracket the measured number.
By their numbers in this assay, from the lowest: compounds 1 and 3 (each within the scatter of the next); then compound 2.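

Adding a second fluoro gives a 2.0-fold lower number from compound 2 to compound 3 (0.31 log units; beyond the scatter) in this assay and shows that this aromatic carbon responds to substitution, even though the group entering is only a single atom. For the compounds shown here, the only earlier step exchanged methyl for fluoro and raised the number, whereas this exchange of hydrogen for fluoro lowers it. No measurement at hand explains this shift. As far as these compounds go, it remains open whether a methoxy group or an amine on this carbon would lower the number further, and whether fluoro here would give a similar step without the existing fluoro group.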